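The source may hold more compounds than are shown below. What is called first, only, known or untested is meant among the compounds shown, and "the series" means these compounds.

Compound 3 `Oc1cc(C(F)(F)F)ccc1-c1nc(-c2ccccc2O)n(-c2ccccc2Cl)n1` was tested in a functional assay on PC-12 cells (Rattus norvegicus) for cytotoxicity, read by MTT assay, with stated times of 2 h and 24 h, tested at 5 uM (on this read-out lower numbers stand for a weaker effect and higher numbers for a stronger effect at the one concentration tested), and gave 90.6%. Its two neighbours among the measured compounds are compound 1 `CCc1ccc(-n2nc(-c3ccc(C(F)(F)F)cc3O)nc2-c2ccccc2O)cc1`, which in this assay gave 95.4%, and compound 2 `CC(C)c1ccc(-n2nc(-c3ccc(C(F)(F)F)cc3O)nc2-c2ccccc2O)cc1`, which in this assay gave 100%. Compound 3 thus has the lowest number of the three, but the steps of a number 4.8 percentage points lower from compound 1 to compound 3 (within the scatter) and a number 9.4 percentage points lower from compound 2 to compound 3 (within the scatter) both lie within the scatter, as does a number 4.6 percentage points higher from compound 1 to compound 2 (within the scatter), so the three compounds are not separated by these measurements.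

Compound 4 `Oc1cc(C(F)(F)F)ccc1-c1nc(-c2ccccc2O)n(-c2ccc(Cl)cc2Cl)n1` differs from compound 3 by chloro in place of hydrogen on an aromatic carbon, which, cut one bond further out, reads 2-chlorophenyl to 2,4-dichlorophenyl. Among the compounds with values here, no measured step changes a group on this ring in this way; the steps from compound 1 to compound 3 and from compound 2 to compound 3 exchange the whole aryl group on the aromatic nitrogen and remain within the scatter. Compound 4 is therefore expected to show a step of a number 1.4 percentage points higher from compound 3 to compound 4 (within the scatter), with no change beyond the scatter anticipated. For compound 4 the estimate in this assay is 92%, with a range from 80% to 100%.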

Compound 4, a percentage reported as activity, at one concentration (the size of the read-out at that concentration, not a potency): 86.7%
For compound 4 the middle estimate is 5.3 percentage points above the measured one; low and high end bracket the measured number.
By their numbers in this assay, from the lowest: compounds 4, 3, 1 and 2 (each within the scatter of the next, the first and the last beyond it).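

The added chloro group, on the aromatic carbon para to a large group and meta to a chloro group, gives a number 3.9 percentage points lower from compound 3 to compound 4 (within the scatter) in this assay, so this position carries a second chloro group without a step that can be told from the scatter. Within the data shown here, exchanging the whole aryl group on the aromatic nitrogen gives a number 8.7 percentage points lower from compound 1 to compound 4 (within the scatter) and also a number 13.3 percentage points lower from compound 2 to compound 4 (beyond the scatter), and that last step is the first in the set to pass the scatter, though only modestly. Nothing at hand bears on why the numbers fall this way.

As far as these compounds go, it stays open how an amine or a methoxy group on this same carbon would read in this assay. From the compounds shown here alone, it also stays open whether the chloro groups or the absence of the 4-isopropyl group carry the gap between these two compounds.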